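The source may report more compounds than this note shows. Statements on the series, on what has been measured and on what is new or still open speak of the compounds shown alone.

Measured compounds:
- compound 1, `COc1ccnc(Nc2ccc(Cl)c(OCC=C(C)C)c2)n1`: 9000 nM
- compound 2, `CC(C)=CCOc1cc(Nc2ccccn2)ccc1C#N`: 290 nM
- compound 3, `CC(C)=CCOc1cc(Nc2nccs2)ccc1C(C)C`: 31000 nM

All three were tested in a functional assay on MT2 cells (Homo sapiens) for cytotoxicity; on this read-out higher numbers stand for lower toxicity in this test and lower numbers for higher toxicity in this test. Among these three numbers compound 1 stands second highest: compound 3 gives a higher number, and compound 2 gives a markedly lower one, with both gaps lying beyond the usual scatter of this assay. The three compounds differ from one another in several places at once, so no single change can be read from their values.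

Compound 4, `CSc1ccnc(Nc2ccc(Cl)c(OCC=C(C)C)c2)n1`, has not yet been measured. It differs from compound 1 in one place only: methylsulfanyl in place of methoxy on an aromatic carbon. For the measured compounds named here, no measured pair shows this kind of change, so there is no step of the same kind to lean on. Because the change is small and the rest of the structure is that of compound 1 with 9000 nM, the step of a 1.3-fold lower number from compound 1 to compound 4 (0.11 log units; within the scatter) is expected to stay within the scatter, or at most lean toward a lower number. Compound 4 is therefore expected to give about 7000 nM, within a range from 2500 nM to 20000 nM.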

Compound 4, half-maximal cytotoxic concentration: 2800 nM
Beside the measured number, compound 4's estimate is 2.5-fold (0.40 log units) above it; the range from low to high includes it.
By their numbers in this assay, from the lowest: compound 2; then compound 4; then compound 1; then compound 3.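

In this assay, for the compounds shown here, putting methylsulfanyl in place of methoxy gives a 3.2-fold lower number from compound 1 to compound 4 (0.51 log units; beyond the scatter), the first comparison here in which only one place changes. It shows that this position, an aromatic carbon next to the ring nitrogen, is not indifferent to the group it carries: exchanging oxygen for sulfur, with the same count of heavy atoms and hydrogen-bond acceptors, moves the read-out toward higher toxicity in this test. No measurement at hand explains this shift.

This single pair cannot show whether the trend follows the linking atom or the size of the group, which a methylamino group or a longer chain such as ethoxy at the same position could help separate. It also leaves open whether the same exchange would produce a similar step on a different core.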